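The source may hold more compounds than are shown below. What is called first, only, known or untested is meant among the compounds shown, and "the series" means these compounds.

Measured in a functional assay on MDA-MB-468 cells (Homo sapiens) for antiproliferative activity, read by MTT assay, with a stated time of 72 h; a higher number here means a weaker inhibitor, a lower number a stronger inhibitor:
- compound 1 `CCCn1ccnc1-c1cc(OC)c(OC)c(OC)c1`: > 100000 nM
- compound 2 `CCCCCn1ccnc1-c1cc(OC)c(OC)c(OC)c1`: 57900 nM
- compound 3 `COc1cc(-c2nccn2-c2ccc3sccc3c2)cc(OC)c1OC`: 400 nM

Compound 1 has no number in this assay, only a limit: the limit of > 100000 nM in this assay, at which 1 of the 3 values shown sits. Compound 4 `COc1cc(-c2nccn2-c2cccc(C)c2)cc(OC)c1OC` departs from it by one change, 3-methylphenyl in place of propyl on an aromatic nitrogen.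

For the measured compounds named here, the only measured step from compound 1 is a longer chain, an at least 1.7-fold lower number from compound 1 to compound 2 (0.23 log units; that floor lies within the scatter), and it says little about an aromatic group at this place. Compound 3 is the better guide, as it also carries an aromatic group on that nitrogen. Compound 3 gives 400 nM, a much lower number than compound 2 at 57900 nM. A large step towards lower numbers in this assay is therefore expected, though the group in compound 4 is smaller than that in compound 3. The step stays uncertain because the start is the limit of compound 1 at > 100000 nM.

The expected change is an at least 66-fold lower number from compound 1 to compound 4 (1.82 log units; beyond the scatter).

For compound 4 the estimate is 1500 nM, with an expected range of 200 nM to 15000 nM.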

Compound 4, half-maximal inhibitory concentration: 22600 nM
Beside the measured number, compound 4's estimate is 15-fold (1.18 log units) below it; the measured number lies above the stated range.
By their numbers in this assay, from the lowest: compound 3; then compound 4; then compound 2. At a limit, above all of these: compound 1.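

In this assay the change to 3-methylphenyl in place of pentyl gives a 2.6-fold lower number from compound 2 to compound 4 (0.41 log units; beyond the scatter) and no more than that modest step, so an aromatic group on this nitrogen does not by itself reach the level of compound 3. In this assay compound 3 gives 400 nM and compound 4 gives 22600 nM with only the group on this nitrogen differing, so which aromatic group sits there counts for far more than the presence of one. Compound 1 stands at a limit, and an at least 4.4-fold lower number from compound 1 to compound 4 (0.64 log units; beyond the scatter) is therefore only a floor for the step: the limit of > 100000 nM in this assay, at which 1 of the 4 values shown sits.

From the compounds shown here alone, whether an unsubstituted phenyl, or a methoxy or an amine in place of the methyl, would bring the number nearer that of compound 3 stays open. So does how a chain longer than pentyl compares with 3-methylphenyl.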